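Compound 3 and its diethylamino analogue, compound 4

The compounds below may be only part of what the source reports. "The series", "measured", "known", "first", "only" and "open" are said of these compounds alone.

Compound 3 (`CC(NC(=O)CN)C(=O)N(C)c1ccc(Cl)cc1C(=O)c1ccccc1Cl`) stands lowest of the three numbers in a functional assay on the whole organism for antagonist activity, with Mus musculus as the target (on this read-out lower numbers stand for an effect already at smaller amounts and higher numbers for an effect only at larger amounts of compound), with 0.47 mg/kg as its value. Compound 1 (`NCC(=O)NCC(=O)Nc1ccc([N+](=O)[O-])cc1C(=O)c1ccccc1`) is the nearest at 4.82 mg/kg and compound 2 (`NC(C(=O)NCC(=O)Nc1ccc(Cl)cc1C(=O)c1ccccc1)c1ccccc1`) the furthest at 28 mg/kg on the same read-out, both gaps beyond the scatter.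

Compound 4 (`CCN(CC)CC(=O)NCC(=O)N(C)c1ccc(Cl)cc1C(=O)c1ccccc1Cl`) differs from compound 3 by ((((diethylamino)methyl)carbonyl)amino)methyl in place of 1-(((aminomethyl)carbonyl)amino)ethyl on a carbonyl carbon on a carbonyl carbon, with ((((diethylamino)methyl)carbonyl)amino)methyl in place of 1-(((aminomethyl)carbonyl)amino)ethyl. Within the data shown here, no two measured compounds differ in one place only, so the series offers no direct guide to the size of this change. Among the measured compounds shown here, with compound 3 at 0.47 mg/kg as the lowest value so far, a move towards a higher number is the likelier direction. The expected step is an 8.5-fold higher number from compound 3 to compound 4 (0.93 log units; beyond the scatter) in this assay and is expected to lie beyond the scatter, though with wide uncertainty. Compound 4 is estimated at 4 mg/kg with an expected range of 0.8 mg/kg to 25 mg/kg for now.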

Compound 4, dose for half-maximal effect: 2.2 mg/kg
Compound 4: middle estimate off by 1.8-fold (0.26 log units), on the high side; measured number inside the range.
By their numbers in this assay, from the lowest: compound 3; then compound 4; then compound 1; then compound 2.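

Notes on the position: on a carbonyl carbon whose other neighbours are: amide-type nitrogen, ((((diethylamino)methyl)carbonyl)amino)methyl in place of 1-(((aminomethyl)carbonyl)amino)ethyl gives the first single-place reading in this assay (a 4.7-fold higher number from compound 3 to compound 4 (0.67 log units; beyond the scatter)), so this place takes a group of 10 heavy atoms in place of 7, with 1 hydrogen-bond donor in place of 2, at a modest cost. Among these compounds, the change alters the amine end of the chain and removes the branch of the ethyl at once, so the one step covers both alterations. No measurement available here accounts for the step.

On these data alone, how the step divides between the diethylamino end and the lost branch stays open. A dimethylamino or pyrrolidine end on either chain would bear on that, as would a longer chain at this place.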